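A few compounds are considered here, and "the series" means these few. Any claim that something is new, unique, unknown or untested is made for them only; others in the source may bear on it.

Working notes on the series. Compound 1 `COc1ccc(CNC(=O)c2cccc(C(C)Oc3ccnc(Nc4cnn(C)c4)c3)c2)cc1OC` and compound 2 `COc1cc(CNC(=O)c2cccc(C(C)Oc3ccnc(Nc4cnn(C)c4)c3)c2)cc(OC)c1OC` share a core and differ only in one ring substituent. In a functional assay on HCC78 cells (Homo sapiens) for antiproliferative activity, read by MTT assay, with a stated time of 48 h (a lower number here means a stronger inhibitor, a higher number a weaker inhibitor), compound 1 gives 76600 nM and compound 2 gives 73900 nM. Within the data shown here, compound 2 stands lowest of the two numbers, but its only neighbour is compound 1, and the step of a 1.0-fold lower number from compound 1 to compound 2 (0.02 log units; within the scatter) does not separate the two.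

Compound 3 `CC(Oc1ccnc(Nc2cnn(C)c2)c1)c1cccc(C(=O)NCc2ccc(C#N)cc2)c1` is not yet measured. Relative to compound 2 the change is 4-cyanophenyl in place of 3,4,5-trimethoxyphenyl on a saturated chain carbon bound to an amide-type nitrogen. Among the measured compounds shown here, the one measured step, methoxy in place of hydrogen, touches the same ring and was within the scatter; the present change also removes that ring's methoxy groups, so no step beyond the scatter is expected in this assay, in either direction. For compound 3 the expected value is 70000 nM, estimated within 25000 nM to 200000 nM, an expected step of a 1.1-fold lower number from compound 2 to compound 3 (0.02 log units; within the scatter).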

Compound 3, half-maximal inhibitory concentration: 8700 nM
Beside the measured number, compound 3's estimate is 8.0-fold (0.91 log units) above it; measured number below the stated range.
By their numbers in this assay, from the lowest: compound 3; then compounds 2 and 1 (each within the scatter of the next).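

At the position on a saturated chain carbon bound to an amide-type nitrogen, the aryl group can shift the number in this assay: 4-cyanophenyl in place of 3,4,5-trimethoxyphenyl gives an 8.5-fold lower number from compound 2 to compound 3 (0.93 log units; beyond the scatter), and 4-cyanophenyl in place of 3,4-dimethoxyphenyl gives an 8.8-fold lower number from compound 1 to compound 3 (0.94 log units; beyond the scatter). The earlier methoxy step on this ring showed no such sensitivity, so compound 1 and compound 2 stand together, with compound 3 clearly lower than both. Nothing measured here accounts for the size of these steps.

The compounds shown do not separate the loss of the methoxy groups from the arrival of the nitrile, a question that an unsubstituted phenyl ring would address. Also open, as far as these compounds go, is whether a primary amide or a carboxylic acid in place of the nitrile would keep the lower number.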